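Tert-Butyl in Place of Fluoro on the Benzyl Ring

The source may hold more compounds than are shown below. What is called first, only, known or untested is meant among the compounds shown, and "the series" means these compounds.

Within the data shown here, three measured compounds share one core and differ only in the single group carried on the benzyl ring. Compound 1 `Cc1ccc(CN2CCc3ncn(COCc4ccccc4)c3/C(=C/c3ccccc3)C2=O)cc1` gives 11400 nM in a functional assay on A549 cells (Homo sapiens) for inhibition, read by MTT assay, with a stated time of 72 h; on this read-out lower numbers stand for stronger inhibition and higher numbers for weaker inhibition. Compound 2 `O=C1/C(=C\c2ccccc2)c2c(ncn2COCc2ccccc2)CCN1Cc1ccc(F)cc1` gives 19600 nM in this assay, and compound 3 `O=C1/C(=C\c2ccccc2)c2c(ncn2COCc2ccccc2)CCN1Cc1ccc(-c2ccccc2)cc1` gives 18300 nM in this assay. Compound 2 carries the highest of the three numbers, yet the step of a 1.7-fold higher number from compound 1 to compound 2 (0.24 log units; within the scatter) and the step of a 1.1-fold lower number from compound 2 to compound 3 (0.03 log units; within the scatter) both lie within the scatter, as does a 1.6-fold higher number from compound 1 to compound 3 (0.21 log units; within the scatter), so no real order among the three can be read from these values.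

Compound 4 `CC(C)(C)c1ccc(CN2CCc3ncn(COCc4ccccc4)c3/C(=C/c3ccccc3)C2=O)cc1` has not yet been measured. It differs from compound 2 in one place: tert-butyl in place of fluoro on an aromatic carbon. The measured steps that bear on this are the exchange of methyl for fluoro, a 1.7-fold higher number from compound 1 to compound 2 (0.24 log units; within the scatter), and the exchange of fluoro for phenyl, a 1.1-fold lower number from compound 2 to compound 3 (0.03 log units; within the scatter); neither moved the number beyond the scatter, and the phenyl of compound 3 is the nearest guide to a larger carbon group entering at this position. The expectation is therefore that the change to compound 4 stays within the scatter, with an expected step of a 1.3-fold lower number from compound 2 to compound 4 (0.12 log units; within the scatter). Compound 4 is estimated at 15000 nM, with a range from 6000 nM to 35000 nM.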

Compound 4, half-maximal inhibitory concentration: 20600 nM
Estimate against measurement, compound 4: 1.4-fold (0.14 log units) below; the range from low to high includes it.
By their numbers in this assay, from the lowest: compounds 1, 3, 2 and 4 (each within the scatter of the next).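

Placing tert-butyl, with four heavy atoms, where fluoro has one, on this aromatic carbon para to a large group gives a step in this assay that lies within the scatter (a 1.1-fold higher number from compound 2 to compound 4 (0.02 log units; within the scatter)). The tert-butyl group also stands within the scatter of the phenyl and methyl groups (a 1.1-fold higher number from compound 3 to compound 4 (0.05 log units; within the scatter); a 1.8-fold higher number from compound 1 to compound 4 (0.26 log units; within the scatter)), so this branched alkyl group joins a single halogen atom, a small alkyl group and an aromatic ring in a set of four whose values cannot be put in any real order. No measurement shown here explains why the number stays so flat across these four groups.

From the compounds shown here alone, all four groups on the benzyl ring are free of hydrogen-bond donors and acceptors and carry no net charge, so it remains open whether an amine, a carboxylic acid or a hydroxyl group at this position would move the number beyond the scatter. The rest of the shared core is identical in all four compounds, which leaves open whether a change elsewhere, such as replacing the benzyloxymethyl group, would have a larger effect.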